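The compounds below may be only part of what the source reports. "The series", "measured", "known", "first", "only" and "open" are said of these compounds alone.

Measured in an ADME assay on microsomes from liver (Mus musculus) for metabolic stability, read by LC-MS, with a stated time of 30 min, tested at 1 ug/mL; a higher number here means that more of the compound is left, a lower number that less of the compound is left:
Compound 1 `Cc1ccc2nc([C@H](CC3CCN(C(=O)C(C)C)CC3)N3C(=O)CN(c4ccc(Oc5ccc(F)cc5)cc4)C3=O)n(C3CC3)c2c1` gives 43%
Compound 2 `CC(C)C(=O)N1CCC(C[C@@H](c2nc3ccccc3n2C2CC2)N2C(=O)CN(c3ccc(Oc4ccc(F)cc4)cc3)C2=O)CC1` gives 29.4%
Compound 3 `CC(C)C(=O)N1CCC(C[C@@H](c2nc3ccc(F)cc3n2C)N2C(=O)CN(c3ccc(Oc4ccc(F)cc4)cc3)C2=O)CC1` gives 26.4%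

Compound 3, at 26.4%, lies within the scatter of compound 2, and the two share the low end of this small set. Compound 1 stands beyond the scatter above compound 3. The unmeasured compound 4 `Cc1ccc2nc([C@H](CC3CCN(C(=O)C(C)C)CC3)N3C(=O)CN(c4ccc(Oc5ccc(F)cc5)cc4)C3=O)n(C)c2c1` differs from compound 3 by methyl in place of fluoro on an aromatic carbon.

Among the compounds with values here, two measured steps bear on this change. The first is a number 13.6 percentage points lower from compound 1 to compound 2 (beyond the scatter), and read in reverse it links the methyl group that compound 1 carries and compound 2 lacks to a higher number. That evidence comes only from compounds carrying 1-cyclopropyl-1H-benzimidazol-2-yl. The second is a number 3 percentage points lower from compound 2 to compound 3 (within the scatter), but it changes the substituents together, so it isolates neither of them. Within the data shown here, no measured pair tests methyl against fluoro directly, and the upward move seen with compound 1 may carry over only in part. The expected move is therefore upward and smaller than that single measured step, and the estimate is a number 9.6 percentage points higher from compound 3 to compound 4 (within the scatter). For compound 4 the estimated value is 36%, with an expected range from 23% to 50%.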

Compound 4, percent of the compound remaining: 10.6%
Compound 4: the middle estimate sits 25.4 percentage points above what was measured, outside the stated range (below it).
By their numbers in this assay, from the lowest: compound 4; then compounds 3 and 2 (each within the scatter of the next); then compound 1.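

In this assay, within the data shown here, the direct exchange on the aromatic carbon gives a number 15.8 percentage points lower from compound 3 to compound 4 (beyond the scatter), so with methyl on the aromatic nitrogen, the methyl group on this carbon stands lower than fluoro, a comparison that the earlier step from methyl to hydrogen, seen only with cyclopropyl on that nitrogen, could not provide. The group on the aromatic nitrogen also proves to matter with the methyl group kept on the aromatic carbon: methyl in place of cyclopropyl gives a number 32.4 percentage points lower from compound 1 to compound 4 (beyond the scatter), the largest step in the set, while the exchange of the whole 1-cyclopropyl-1H-benzimidazol-2-yl for 1,6-dimethyl-1H-benzimidazol-2-yl gives a number 18.8 percentage points lower from compound 2 to compound 4 (beyond the scatter). Nothing shown here explains these differences in this assay.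

The compounds shown leave open how fluoro compares with methyl on the aromatic carbon when cyclopropyl sits on the aromatic nitrogen, and how hydrogen compares with either when methyl sits there. They also leave open where chloro or methoxy on that carbon, or ethyl on that nitrogen, would fall in this assay.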